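Extending the ketone chain in a bile acid receptor antagonist

The source may hold more compounds than are shown below. What is called first, only, known or untested is meant among the compounds shown, and "the series" means these compounds.

Measured compounds:
compound 1, `CCc1cc(C(C)=O)c(OC)cc1OCCCCCC(C)(C)c1nnn[nH]1`: 5500 nM
compound 2, `CCC(=O)c1cc(CC)c(OCCCCCC(C)(C)c2nnn[nH]2)cc1O`: 8500 nM

Both compounds were tested in an assay on isolated protein for antagonist activity at Bile acid receptor (Homo sapiens), read by HTRF, with a stated time of 30 min; on this read-out lower numbers stand for stronger inhibition and higher numbers for weaker inhibition. Compound 2 gives the higher of the two numbers, yet its gap to compound 1 lies within the usual scatter of repeated measurements, so the two cannot be told apart on these data.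

Compound 3, `CCCCCCC(=O)c1cc(CC)c(OCCCCCC(C)(C)c2nnn[nH]2)cc1O`, has not yet been measured. It differs from compound 2 in one place: butyl in place of hydrogen on a saturated chain carbon, two bonds along the chain from a carbonyl carbon. Going by the values given here, no measured pair shows the effect of such a change, so nothing here indicates its direction. The step from compound 2 to compound 3 is therefore expected to stay within the scatter, as a 1.4-fold lower number from compound 2 to compound 3 (0.15 log units; within the scatter), with a wide allowance either way. Compound 3 is accordingly estimated at 6000 nM, somewhere in the range from 1500 nM to 25000 nM.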

Compound 3, half-maximal inhibitory concentration: 8400 nM
Compound 3: middle estimate off by 1.4-fold (0.15 log units), on the low side, within the range that was stated.
By their numbers in this assay, from the lowest: compounds 1, 3 and 2 (each within the scatter of the next).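

In this assay, putting butyl in place of hydrogen on a saturated chain carbon, two bonds along the chain from a carbonyl carbon, gives a 1.0-fold lower number from compound 2 to compound 3 (0.01 log units; within the scatter) and leaves the two compounds indistinguishable. Going by these compounds alone, this is the first measured pair to show such a change, and it shows that this position can carry 4 more heavy atoms, turning propanoyl into hexylcarbonyl, without any readable difference in this read-out. Nothing measured here gives a reason for this result.

As far as these compounds go, whether a longer chain, a phenyl ring, an amine or a carboxylic acid in place of butyl would give a number beyond the scatter stays open. A single pair also cannot say whether methyl or ethyl in place of hydrogen at this carbon would behave the same way.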